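Swapping the benzothiazole for a saturated bicyclic imidazole

The compounds below may be only part of what the source reports. "The series", "measured", "known", "first", "only" and "open" are said of these compounds alone.

Among the measured compounds shown here, compound 2 `CCCCCCN(CCCCCSc1nc2ccccc2s1)C(=O)Nc1ccc(F)cc1F` gives 4000 nM in an assay on microsomes from liver for inhibition of sterol O-acyltransferase 1 (Rattus norvegicus) (on this read-out lower numbers stand for stronger inhibition and higher numbers for weaker inhibition), and holds the lowest of the two numbers; its only neighbour, compound 1 `CCCCCCN(CCCCCSc1nc2ccccc2o1)C(=O)Nc1ccc(F)cc1F`, gives 51000 nM. Compound 3 `CCCCCCN(CCCCCSc1nc2c([nH]1)CCCC2)C(=O)Nc1ccc(F)cc1F` carries a group of 9 heavy atoms (7 carbon, 2 nitrogen; one five-membered aromatic ring with 2 hetero atoms, one six-membered non-aromatic ring of carbon only) in place of a group of 9 heavy atoms (7 carbon, 1 nitrogen, 1 sulfur; one five-membered aromatic ring with 2 hetero atoms, one six-membered aromatic ring of carbon only), on a sulfur. For the measured compounds named here, the one measured step, a 13-fold lower number from compound 1 to compound 2 (1.11 log units; beyond the scatter), shows that exchanging the hetero atoms of this ring system moves the read-out strongly, but it covers a different exchange. A moderate step is therefore expected, with the direction uncertain, so compound 3 is estimated at 8000 nM within 1500 nM to 40000 nM, a change of a 2.0-fold higher number from compound 2 to compound 3 (0.30 log units; within the scatter).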

Compound 3, half-maximal inhibitory concentration: 810 nM
For compound 3 the middle estimate is 9.9-fold (0.99 log units) above the measured one, outside the stated range (below it).
By their numbers in this assay, from the lowest: compound 3; then compound 2; then compound 1.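

Replacing the 1,3-benzothiazol-2-yl on the sulfur gives a 4.9-fold lower number from compound 2 to compound 3 (0.69 log units; beyond the scatter) in this assay, so a six-membered aromatic ring of carbon is not required here for the lowest number of the three. The same group gives a 63-fold lower number from compound 1 to compound 3 (1.80 log units; beyond the scatter) against the 1,3-benzoxazol-2-yl. Nothing available says which part of the exchange, the non-aromatic ring, the second nitrogen or the hydrogen-bond donor, accounts for this. Open, from the compounds shown here alone, is whether a 1H-benzimidazol-2-yl, which keeps the donor on an aromatic carbon ring, matches compound 3, and whether a methyl on that ring nitrogen preserves the number.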